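This account rests on a few compounds, and the source may have more. Where it says the series, first, only, none or still open, it means among the compounds named here.

Measured so far in an assay for inhibition of sodium- and chloride-dependent glycine transporter 1 (Homo sapiens); on this read-out higher numbers stand for weaker inhibition and lower numbers for stronger inhibition:

- compound 1 `COc1ccc(Sc2ccc(Cl)cc2N2CCN(CC(=O)O)C(C)C2)cc1` gives 290 nM
- compound 2 `COc1ccc(Sc2ccccc2N2C[C@H](C)N(CC(=O)O)C[C@H]2C)cc1` gives 53000 nM
- compound 3 `COc1ccc(Sc2ccccc2N2CCN(CC(=O)O)CC2C)cc1` gives only a limit of the assay, > 10000 nM

Compound 1 holds the lowest of the two numbers shown; the number for compound 2 lies far higher, well beyond the scatter, but the two structures differ in more than one place, so no single step can be read from that pair. Of compound 3 only a limit is known; it sits at the limit of > 10000 nM in this assay, at which 1 of the 3 values shown sits, and gives no number to compare.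

Compound 4 `COc1ccc(Sc2ccc(C)cc2N2CCN(CC(=O)O)C(C)C2)cc1` has not been measured. It differs from compound 1 in one place: methyl in place of chloro on an aromatic carbon. Within the data shown here, no measured pair in this set isolates that change, so no step size can be drawn from the data; the expectation rests on compound 1 and the small size of the exchange. The step of a 1.7-fold higher number from compound 1 to compound 4 (0.24 log units; within the scatter) is expected to be modest, if anything toward a somewhat higher number, and may well stay within the scatter. For compound 4 the estimated value in this assay is 500 nM, with a range of 150 nM to 2000 nM.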

Compound 4, half-maximal inhibitory concentration: 1600 nM
The estimate for compound 4 lay 3.2-fold (0.51 log units) below the measured number, and the stated range covers the measured number.
By their numbers in this assay, from the lowest: compound 1; then compound 4; then compound 2.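

In this assay, among these compounds, the exchange of chloro for methyl gives a 5.5-fold higher number from compound 1 to compound 4 (0.74 log units; beyond the scatter), the first step that can be read from a change in one place. The position para to the (4-methoxyphenyl)sulfanyl group therefore responds to this exchange, although the two groups match in heavy-atom count and neither carries a hydrogen-bond donor or acceptor, and chloro gives the lower number of the two. Nothing measured here accounts for the size of the step.

Still open, from the compounds shown here alone, is how fluoro, trifluoromethyl, methoxy or nitrile would fare at this position, and how plain hydrogen there would compare with chloro on the core of compound 1. Going by these compounds, it is also open whether the step keeps its size when the rest of the molecule changes.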